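The compounds below may be only part of what the source reports. "The series", "measured", "known", "first", "only" and "open" are said of these compounds alone.

The study sets four compounds on a shared core against each other. Among the compounds with values here, compound 3 `COc1cc(-c2nn(-c3cccc(NC(=O)Nc4ccc(Cl)c(C(F)(F)F)c4)c3)cc2-c2ccncc2)ccc1Cl` is the only one that returns a number in a functional assay on OVCAR-4 cells (Homo sapiens) for inhibition, read by sulforhodamine B assay, with a stated time of 48 h; a higher number here means a weaker inhibitor of growth, a lower number a stronger inhibitor of growth: there compound 3 gives 25600 nM. Compound 1 `COc1cc(-c2nn(-c3cccc(NC(=O)Nc4ccc(Cl)c(Cl)c4)c3)cc2-c2ccncc2)ccc1Cl` reaches only a limit in this assay, where compound 1 gives > 50000 nM. Compound 2 `COc1cc(-c2nn(-c3cccc(NC(=O)c4ccc(Cl)c(C(F)(F)F)c4)c3)cc2-c2ccncc2)ccc1Cl` likewise reaches only a limit in this assay, where compound 2 gives > 32500 nM. Among the measured steps, an at least 1.9-fold lower number from compound 1 to compound 3 (0.29 log units; that floor lies within the scatter) and an at least 1.2-fold lower number from compound 2 to compound 3 (0.10 log units; that floor lies within the scatter) have floors within the scatter, and a step that the two limits leave unreadable from compound 1 to compound 2. Compound 4 `COc1cc(-c2nn(-c3cccc(NC(=O)c4ccccc4)c3)cc2-c2ccncc2)ccc1Cl` is not yet measured; it differs from compound 3 by phenyl in place of (4-chloro-3-(trifluoromethyl)phenyl)amino on a carbonyl carbon. The step from compound 2 to compound 3 bears on this most closely, as it also exchanges an amide for a urea on that carbonyl carbon, but compound 4 additionally gives up the chloro and trifluoromethyl groups that compound 1 and compound 2 carry in their own forms. With two of three neighbours sitting at limits, the expected step of a 1.6-fold higher number from compound 3 to compound 4 (0.19 log units; within the scatter) points toward a higher number, though the data cannot fix its size. Compound 4 is therefore estimated at 40000 nM, within a range from 15000 nM to 100000 nM.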

Compound 4, concentration for total growth inhibition: > 100000 nM
Compound 4: no number, only a limit; the forecaster's own chance of this, stated with the estimate: 50%; middle value at least 2.5-fold (0.39 log units) away from the limit.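

Compound 4 gives no number, only a limit, in this assay: the limit of > 100000 nM in this assay, at which 1 of the 4 values shown sits.

Even so, phenyl in place of (4-chloro-3-(trifluoromethyl)phenyl)amino on this carbonyl carbon gives a readable floor (an at least 3.9-fold higher number from compound 3 to compound 4 (0.59 log units; beyond the scatter)), and it is the first step in this set to lie beyond the scatter. Growth inhibition at this position therefore does respond to this change, which the earlier steps could not establish. The steps to compound 4 from compound 1 and from compound 2 cannot be read, as each joins two limits.

This change removes the amino link and the chloro and trifluoromethyl groups together, and the compounds shown do not separate their contributions. Going by these compounds, whether a carboxylic acid or a dimethylamino group on the phenyl of compound 4 would change its reading also remains open.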